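The source may hold more compounds than are shown below. What is called first, only, known or untested is meant among the compounds shown, and "the series" means these compounds.

Compound 1 `CN1CCN(CC(=O)Nc2nc3ccccc3[nH]2)CC1`, compound 2 `O=C(CN1CCN(c2ccccc2)CC1)Nc1nc2ccccc2[nH]1` and compound 3 `O=C(CN1CCN(c2ccccn2)CC1)Nc1nc2ccccc2[nH]1` share one core and differ only in the group carried on an amine nitrogen in a ring. In a functional assay, read by spectrophotometry, with a stated time of 30 min, tested at 150 ug/mL (on this read-out lower numbers stand for a weaker effect and higher numbers for a stronger effect at the one concentration tested), compound 1 gives 54.3%, compound 2 gives 40.6% and compound 3 gives 69.1%, the highest of the three numbers, with both other compounds beyond the scatter below it. Two steps lead up to compound 3: a number 14.8 percentage points higher from compound 1 to compound 3 (beyond the scatter) and a number 28.5 percentage points higher from compound 2 to compound 3 (beyond the scatter), while a number 13.7 percentage points lower from compound 1 to compound 2 (beyond the scatter). Compound 4 `O=C(CN1CCN(c2ncccn2)CC1)Nc1nc2ccccc2[nH]1` takes one further step from compound 3: pyrimidin-2-yl in place of pyridin-2-yl on an amine nitrogen in a ring. Among the compounds with values here, the steps that bear on this change are the two modest, upward ones into compound 3, and of these the step that put pyridin-2-yl in place of phenyl was the larger. In this assay compound 4 is therefore expected to give 72%, within a range from 55% to 88%. This amounts to an expected a number 2.9 percentage points higher from compound 3 to compound 4 (within the scatter), small or none beyond the scatter.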

Compound 4, a percentage reported as activity, at one concentration (the size of the read-out at that concentration, not a potency): 68.4%
Estimate against measurement, compound 4: 3.6 percentage points above, and the stated range covers the measured number.
By their numbers in this assay, from the lowest: compound 2; then compound 1; then compounds 4 and 3 (each within the scatter of the next).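

Pyrimidin-2-yl, with 2 hetero atoms in its ring, and pyridin-2-yl, with 1, cannot be told apart at this position in this assay: a number 0.7 percentage points lower from compound 3 to compound 4 (within the scatter). The lead over the other two groups also holds for this second ring, a number 27.8 percentage points higher from compound 2 to compound 4 (beyond the scatter) and a number 14.1 percentage points higher from compound 1 to compound 4 (beyond the scatter), so the advantage over phenyl and methyl is now seen with two aromatic rings containing ring nitrogen rather than one. Nothing available explains why these two groups read alike or why phenyl stands apart.

From the compounds shown here alone, it remains open whether a pyridin-4-yl, benzyl or acetyl group on the same nitrogen would read like compound 3 and compound 4 or like compound 2. Going by these compounds, it is also open whether a methoxy or chloro group on the phenyl ring of compound 2 would narrow its gap.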